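A benzyl-for-chlorophenyl exchange repeated on a second core

The source may report more compounds than this note shows. Statements on the series, on what has been measured and on what is new or still open speak of the compounds shown alone.

Compound 1 `O=C(Nc1ccc(Cl)cc1)c1cc(Oc2ccc(/C=C/c3ccccn3)cc2)ccn1` and compound 2 `O=C(NCc1ccccc1)c1cc(Oc2ccc(/C=C/c3ccccn3)cc2)ccn1` share one core and differ only in that compound 2 carries benzyl in place of 4-chlorophenyl on an amide-type nitrogen. In a functional assay on HepG2 cells (Homo sapiens) for antiproliferative activity, read by CCK-8 assay, with a stated time of 48 h (a lower number here means a stronger inhibitor, a higher number a weaker inhibitor), compound 1 gives 31300 nM, and compound 2 gives 27900 nM, so the step from one to the other is a 1.1-fold lower number from compound 1 to compound 2 (0.05 log units; within the scatter). Compound 3 `O=C(Nc1ccc(Cl)cc1)c1cc(Oc2ccc(/C=C/c3ccncc3)cc2)ccn1` keeps the amide of compound 1 but its core differs by pyridin-4-yl in place of pyridin-2-yl on a double-bonded chain carbon bound to a double-bonded chain carbon; in this assay compound 3 gives 56200 nM, a step of a 1.8-fold higher number from compound 1 to compound 3 (0.25 log units; within the scatter). All three values lie within the scatter of one another, so none can be called stronger or weaker.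

Compound 4 `O=C(NCc1ccccc1)c1cc(Oc2ccc(/C=C/c3ccncc3)cc2)ccn1` has not been measured. It differs from compound 3 by benzyl in place of 4-chlorophenyl on an amide-type nitrogen, the same change, at the same kind of amide-type nitrogen, that separates compound 1 from compound 2, now made on the core of compound 3. Because a 1.1-fold lower number from compound 1 to compound 2 (0.05 log units; within the scatter) was small, the step from compound 3 to compound 4 is expected to be equally small, about a 1.1-fold lower number from compound 3 to compound 4 (0.05 log units; within the scatter). Compound 4 is therefore estimated at 50000 nM in this assay, expected to fall between 25000 nM and 100000 nM.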

Compound 4, half-maximal inhibitory concentration: 28900 nM
For compound 4 the middle estimate is 1.7-fold (0.24 log units) above the measured one, within the range that was stated.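

In this assay, benzyl in place of 4-chlorophenyl on the amide-type nitrogen gives a 1.9-fold lower number from compound 3 to compound 4 (0.29 log units; within the scatter), and this step agrees with its earlier counterpart on the other core: the same change on two cores in this assay, a 1.1-fold lower number (0.05 log units; within the scatter) from compound 1 to compound 2 and a 1.9-fold lower number (0.29 log units; within the scatter) from compound 3 to compound 4, 1.7-fold (0.24 log units) apart, within the scatter of two such steps. Pyridin-4-yl in place of pyridin-2-yl gives a 1.0-fold higher number from compound 2 to compound 4 (0.02 log units; within the scatter), and this step likewise agrees with its earlier counterpart: the same change on two cores in this assay, a 1.8-fold higher number (0.25 log units; within the scatter) from compound 1 to compound 3 and a 1.0-fold higher number (0.02 log units; within the scatter) from compound 2 to compound 4, 1.7-fold (0.24 log units) apart, within the scatter of two such steps. The four compounds therefore show no sign that either change behaves differently on the second core, but they do not show that either change transfers as a real effect, since every step is within the scatter and there is no clear shift to carry from one core to the other.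

From the compounds shown here alone, it remains open whether any change at these two places can move the number beyond the scatter. A phenethyl chain on the amide-type nitrogen, a carboxylic acid on the benzyl ring or a pyridin-3-yl group on the double-bonded chain would each put that question to a further test.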